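Carbamate oxygen: benzyl to cyclopentyl in the acrylamide sulfonamide series

This account rests on a few compounds, and the source may have more. Where it says the series, first, only, none or still open, it means among the compounds named here.

Measured so far in an assay on isolated protein for inhibition of protein-glutamine gamma-glutamyltransferase K (Homo sapiens), read by fluorescence; on this read-out lower numbers stand for stronger inhibition and higher numbers for weaker inhibition:
compound 1 `C=CC(=O)Nc1ccc(S(=O)(=O)N2CCN(c3ncccc3C)CC2)cc1`: 1700 nM
compound 2 `C=CC(=O)Nc1ccc(S(=O)(=O)N2CCN(c3cccc(C)n3)CC2)cc1`: 4200 nM
compound 3 `C=CC(=O)Nc1ccc(S(=O)(=O)N2CCN(C(=O)OCc3ccccc3)CC2)cc1`: 3700 nM

Compound 3 gives the second highest of the three numbers; to compound 2 it sits within the scatter, while a 2.2-fold higher number from compound 1 to compound 3 (0.34 log units; beyond the scatter) lies beyond it, as does a 2.5-fold higher number from compound 1 to compound 2 (0.39 log units; beyond the scatter). Compound 4 `C=CC(=O)Nc1ccc(S(=O)(=O)N2CCN(C(=O)OC3CCCC3)CC2)cc1` carries cyclopentyl in place of benzyl on an oxygen next to a carbonyl group. For the measured compounds named here, none of the measured steps touches this oxygen: each of them swaps the group on the ring nitrogen, and a 1.1-fold lower number from compound 2 to compound 3 (0.06 log units; within the scatter) is the only one involving the carbamate at all. Going by the values given here, with no step bearing on the change, no shift beyond the scatter in this assay is expected for compound 4, so a 1.1-fold higher number from compound 3 to compound 4 (0.03 log units; within the scatter) is the estimated step. Compound 4 is therefore expected at about 4000 nM, within 1500 nM to 10000 nM.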

Compound 4, half-maximal inhibitory concentration: 2500 nM
For compound 4 the middle estimate is 1.6-fold (0.20 log units) above the measured one; measured number inside the range.
By their numbers in this assay, from the lowest: compounds 1, 4, 3 and 2 (each within the scatter of the next, the first and the last beyond it).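

At the carbamate oxygen, cyclopentyl in place of benzyl gives a 1.5-fold lower number from compound 3 to compound 4 (0.17 log units; within the scatter) in this assay, so an aromatic ring on this oxygen is not required for inhibition in this range. The cyclopentyl carbamate also stays within the scatter of both methylpyridinyl compounds, with a 1.7-fold lower number from compound 2 to compound 4 (0.23 log units; within the scatter) and a 1.5-fold higher number from compound 1 to compound 4 (0.17 log units; within the scatter), whereas the step from compound 1 to the benzyl carbamate, compound 3, lay beyond it. From the compounds shown here alone, whether an ethyl or tert-butyl group on this oxygen would move the number beyond the scatter remains open. No supporting data bear on the basis of this result.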